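This account rests on a few compounds, and the source may have more. Where it says the series, first, only, none or still open, it means among the compounds named here.

Four compounds sharing one core were looked at in an ADME assay on J774 cells (Mus musculus) for cytotoxicity (on this read-out higher numbers stand for an effect only at larger amounts of compound and lower numbers for an effect already at smaller amounts), and the numbers there are sparse. Compound 1 (`CCCCc1cc2c(=O)c(C(C)=O)c[nH]c2cc1OCCOc1ccccc1`) is recorded as "not determined" (no result reported), so it offers no figure. Within the data shown here, compound 2 (`CCCCc1cc2c(=O)c(C(=O)N(C)C)c[nH]c2cc1OCCOc1ccccc1`) gives 15300 nM, the single number available. Compound 3 (`CCCCc1cc2c(=O)c(I)c(C)[nH]c2cc1OCCOc1ccccc1`) is recorded as "not determined" (no result reported), so it has no place on the scale and cannot be ranked against compound 2. Compound 4 (`CCCCc1cc2c(=O)c(I)c[nH]c2cc1OCCOc1ccccc1`) has yet to be measured. Among the measured compounds shown here, the one structural change that leads to compound 4 is hydrogen in place of methyl on an aromatic carbon, in words hydrogen in place of methyl on an aromatic carbon. For the measured compounds named here, no measured step shows what such a change does. The expected step in this assay is therefore none beyond the scatter, with no direction favoured. The only anchor for the level is compound 2 at 15300 nM. Compound 4 is expected at about 15000 nM, with an estimated range from 5000 nM to 40000 nM.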

Compound 4, half-maximal effective concentration: > 10000 nM
Compound 4 was reported as a limit; the forecaster's own chance of this, stated with the estimate: 25%; the middle value lies beyond the limit too.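

In this assay compound 4 gives > 10000 nM, which is a limit and not a number. No size can be read from it for the step between compound 2 and compound 4. The compounds shown leave open what hydrogen in place of methyl does in this assay.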